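The source may report more compounds than this note shows. Statements on the series, on what has been measured and on what is new or still open speak of the compounds shown alone.

Measured in a functional assay on the whole organism for inhibition, with Cavia porcellus as the target; on this read-out lower numbers stand for an effect already at smaller amounts and higher numbers for an effect only at larger amounts of compound:
compound 1 `CCOC(=O)CC(=O)N1CCSC1COc1ccccc1OC`, 21 mg/kg
compound 2 `COc1ccccc1OCC1SCCN1C(=O)CC(C)=O`, 30 mg/kg

Going by the values given here, compound 2 gives the higher of these two numbers, yet its only neighbour, compound 1, lies within the scatter of it. Compound 3 `COc1ccccc1OCC1SCCN1C(=O)CC(=O)O` differs from compound 2 by hydroxy in place of methyl on a carbonyl carbon. Among the compounds with values here, the single measured step that touches this carbonyl carbon, a 1.4-fold higher number from compound 1 to compound 2 (0.15 log units; within the scatter), stayed within the scatter, so for compound 3 no step beyond the scatter is expected in this assay either. Compound 3 is therefore estimated at 30 mg/kg, between 12 mg/kg and 75 mg/kg, which means an expected step of no change at the digits printed from compound 2 to compound 3 (within the scatter), small in either direction.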

Compound 3, dose for half-maximal effect: 20 mg/kg
Compound 3: the middle estimate sits 1.5-fold (0.18 log units) above what was measured, within the range that was stated.
By their numbers in this assay, from the lowest: compounds 3, 1 and 2 (each within the scatter of the next).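

In this assay the carbonyl carbon now carries a third group, and hydroxy in place of methyl stays within the scatter (a 1.5-fold lower number from compound 2 to compound 3 (0.18 log units; within the scatter)). Hydrogen in place of ethyl on the oxygen next to the carbonyl group does too (a 1.1-fold lower number from compound 1 to compound 3 (0.02 log units; within the scatter)), so the methyl, ethoxy and hydroxy forms cannot be told apart here, even though hydroxy brings a hydrogen-bond donor. No supporting measurement bears on why this change leaves the number within the scatter. On these data alone, whether an amine or a longer chain on this carbonyl carbon would do the same stays open.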